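Working notes on a sulfonyl series: outlook for compound 4

The source may report more compounds than this note shows. Statements on the series, on what has been measured and on what is new or still open speak of the compounds shown alone.

Measured so far:
compound 1 `CCCCCCCCCCCCS(=O)(=O)/C=C/c1ccc(O)c(O)c1`: 8500 nM
compound 2 `C=CCCCCCCS(=O)(=O)/C=C/c1ccc(O)c(O)c1`: 6400 nM
compound 3 `O=S(=O)(/C=C/c1ccc(O)c(O)c1)CCCCCCCCCCCO`: 22600 nM

In a functional assay, read by fluorescence and spectrophotometry, with a stated time of 1 h (on this read-out lower numbers stand for an effect already at smaller amounts and higher numbers for an effect only at larger amounts of compound), compound 2 has the lowest of the three numbers. The step of a 1.3-fold lower number from compound 1 to compound 2 (0.12 log units; within the scatter) is within the scatter, so compounds 1 and 2 cannot be told apart on this read-out; only a 3.5-fold higher number from compound 2 to compound 3 (0.55 log units; beyond the scatter) and a 2.7-fold higher number from compound 1 to compound 3 (0.42 log units; beyond the scatter) stand beyond it, both modest.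

Compound 4 `O=S(=O)(/C=C/c1ccc(O)c(O)c1)CCCC1CCCC1` is not yet measured in this assay. Its change from compound 2 is cyclopentyl in place of pent-4-en-1-yl on a saturated chain carbon, three bonds along the chain from a sulfonyl sulfur. Going by the values given here, two measured steps bear on it. The step from compound 1 to compound 2 also reworked the chain end without adding a donor or acceptor and stayed within the scatter. The steps into compound 3 introduced a hydroxy and moved the number modestly upward; the change into compound 4 brings no such group, its atoms being the same as those of compound 2, only joined differently. On this basis no step beyond the scatter is expected, in either direction, and a 1.1-fold higher number from compound 2 to compound 4 (0.04 log units; within the scatter) is taken as the expected step.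

For compound 4 in this assay the estimate is 7000 nM, with a range from 3500 nM to 14000 nM.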

Compound 4, half-maximal effective concentration: 6300 nM
Estimate against measurement, compound 4: 1.1-fold (0.05 log units) above; the measured number falls inside the stated range.
By their numbers in this assay, from the lowest: compounds 4, 2 and 1 (each within the scatter of the next); then compound 3.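

In this assay, the step of a 1.0-fold lower number from compound 2 to compound 4 (0.01 log units; within the scatter) lies within the scatter, so at this place, on a saturated chain carbon, three bonds along the chain from a sulfonyl sulfur, pent-4-en-1-yl and cyclopentyl cannot be told apart on this read-out. The earlier compounds shown here showed only open chains; compound 4 adds the first case in which the chain end is closed into a five-membered non-aromatic ring of carbon only, and the double bond outside aromatic rings is lost with no step beyond the scatter. Among the compounds shown, the steps beyond the scatter still all lead into compound 3, the one with a hydroxy at the chain end, and this new step does not join them, though no measurement here explains why the swap leaves the number where it stands.

As far as these compounds go, whether the same holds for a larger or flat ring at this place, such as cyclohexyl or phenyl, remains open. Also open, from the compounds shown here alone, is how an amine or a carboxylic acid on the ring or at the chain end would compare with the hydroxy of compound 3, and whether a 2-cyclopentylethyl chain would stay within the scatter of compound 4.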